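A fluoromethyl swap on a compound at the limit

The compounds below may be only part of what the source reports. "The series", "measured", "known", "first", "only" and "open" are said of these compounds alone.

Compound 3 (`COc1cc(C(c2ccc(O)c(OC)c2)[C@H](CO)C(C)C)ccc1O`) stands where the numbers stop being readable. In a functional assay on HeLa cells (Homo sapiens) for cytotoxicity, read by WST assay, with a stated time of 48 h (a lower number here means a stronger inhibitor, a higher number a weaker inhibitor), compound 3 gives > 100000 nM, which is a limit and not a number. In this assay compound 1 (`COc1cc(C(c2ccc(O)c(OC)c2)[C@@H](C)[C@@H](C)CO)ccc1O`) gives > 100000 nM, again a limit. In this assay compound 2 (`COc1cc(C(c2ccc(O)c(OC)c2)[C@@H](C)[C@H](C)CO)ccc1O`) gives > 100000 nM, also a limit.

Compound 4 (`COc1cc(C(c2ccc(O)c(OC)c2)[C@@H](CF)C(C)C)ccc1O`) differs from compound 3 in one group on a saturated chain carbon bound to two aromatic carbons: 1-(fluoromethyl)-2-methylpropyl in place of 1-(hydroxymethyl)-2-methylpropyl on a saturated chain carbon bound to two aromatic carbons.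

The measured changes closest to this one are a step that the two limits leave unreadable from compound 1 to compound 3 and a step that the two limits leave unreadable from compound 2 to compound 3, both of which alter the same group, together with a step that the two limits leave unreadable from compound 1 to compound 2, a change of configuration alone. Among the measured compounds shown here, none of them has a size that can be read, and no measured compound carries the fluoromethyl group, so no step of this kind is available to borrow. The expectation therefore rests on compound 3 itself, with its limit of > 100000 nM. The expected change, a number no higher from compound 3 to compound 4 (the limit leaves the size open), is no clear step in either direction, although this is a weakly founded guess. For compound 4 the estimated value in this assay is 100000 nM, with an expected range from 30000 nM to 300000 nM, and a limit may well be all that is reported.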

Compound 4, half-maximal inhibitory concentration: 41000 nM
Estimate against measurement, compound 4: 2.4-fold (0.39 log units) above; low and high end bracket the measured number.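

In this assay, compound 4 is the only one of the four compounds shown to give a readable number, so 1-(fluoromethyl)-2-methylpropyl in place of 1-(hydroxymethyl)-2-methylpropyl on a saturated chain carbon bound to two aromatic carbons gives an at least 2.4-fold lower number from compound 3 to compound 4 (0.38 log units; beyond the scatter) and not merely another limit. The two compounds that carry 2-(hydroxymethyl)-1-methylpropyl compare with compound 4 in the same way, with an at least 2.4-fold lower number from compound 2 to compound 4 (0.38 log units; beyond the scatter) and an at least 2.4-fold lower number from compound 1 to compound 4 (0.38 log units; beyond the scatter), whereas the steps among compound 1, compound 2 and compound 3 cannot be read. All three new steps give only a minimum size, not a full one, because each starts from a compound without a readable number: the limit of > 100000 nM in this assay, at which 3 of the 4 values shown sit.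

As far as these compounds go, whether a plain methyl, a chloromethyl or an aminomethyl group at this place would also give a readable number stays open, and so does how far the number would move with each of them. From the compounds shown here alone, it is also open whether a fluoromethyl group on the 1-methylpropyl chain of compound 1 and compound 2 would match compound 4, and whether configuration would then matter.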